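Removing the dimethylamino from the anilino ring

The compounds below may be only part of what the source reports. "The series", "measured", "known", "first", "only" and "open" are said of these compounds alone.

Measured so far:
- compound 1 `Cc1cc(-c2ccccn2)nc(Nc2ccc(N(C)C)cc2)n1`: 31900 nM
- compound 2 `Cc1cc(-c2ccco2)nc(Nc2ccc(N(C)C)cc2)n1`: 5900 nM

In a functional assay for inhibition, with Homo sapiens as the target (on this read-out lower numbers stand for stronger inhibition and higher numbers for weaker inhibition), compound 2 gives 5900 nM, the lowest of the two numbers seen so far. Going by the values given here, its nearest neighbour is compound 1, which gives 31900 nM; the only measured step, a 5.4-fold lower number from compound 1 to compound 2 (0.73 log units; beyond the scatter), concerns an exchange on the other side of the shared core. Compound 3 `Cc1cc(-c2ccco2)nc(Nc2ccccc2)n1` differs from compound 2 at the amine-bearing ring: hydrogen in place of dimethylamino on an aromatic carbon. Among the compounds with values here, no measured step touches this part of the molecule, so that step offers no guide to the size or direction of the change, and the expectation below rests on nothing firmer than the pair itself. Compound 3 is expected to show a step of a 2.0-fold higher number from compound 2 to compound 3 (0.31 log units; beyond the scatter), weaker than compound 2 but with a wide range, estimated at 12000 nM between 3000 nM and 50000 nM.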

Compound 3, half-maximal inhibitory concentration: 17700 nM
The estimate for compound 3 lay 1.5-fold (0.17 log units) below the measured number, within the range that was stated.
By their numbers in this assay, from the lowest: compound 2; then compounds 3 and 1 (each within the scatter of the next).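

In this assay, removing the dimethylamino gives a 3.0-fold higher number from compound 2 to compound 3 (0.48 log units; beyond the scatter), the first sign that this part of the molecule affects the read-out and that hydrogen cannot stand in for this group without a loss. The opening step, a 5.4-fold lower number from compound 1 to compound 2 (0.73 log units; beyond the scatter), concerned the other side of the shared core, so both sides now have a measured effect beyond the scatter, and compound 2 remains the lowest at 5900 nM. No measurement shown explains why the number rises when this group leaves.

Going by these compounds, with only dimethylamino and hydrogen at this position, it remains open whether a smaller amine such as methylamino, a larger one such as diethylamino, or a methoxy would keep the lower number. On these data alone, it is also open whether removing the dimethylamino has a similar effect when pyridin-2-yl replaces furan-2-yl.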